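A few compounds are considered here, and "the series" means these few. Any claim that something is new, unique, unknown or untested is made for them only; others in the source may bear on it.

In an ADME assay on Vero cells (Chlorocebus sabaeus) for cytotoxicity, read by resazurin assay, with a stated time of 3 days (on this read-out higher numbers stand for weaker inhibition and lower numbers for stronger inhibition), compound 1 `CCN(CC)c1cc2[nH]c(C3CCCCC3)nc2cc1NC(=O)OCC(F)(F)F` gives > 100 ug/mL, which is a limit of the assay rather than a number. Compound 2 `CN(C)c1cc2[nH]c(C3CCCCC3)nc2cc1NC(=O)OCC(F)(F)F` gives > 100 ug/mL, again only a limit. Compound 3 `CCCOCC(=O)Nc1cc2nc(C3CCCCC3)[nH]c2cc1N1CCCC1` gives > 100 ug/mL, once more a limit. The only one-change step among these, a step that the two limits leave unreadable from compound 1 to compound 2, therefore has no readable size. Compound 2 thus stands at the limit of > 100 ug/mL in this assay, at which 3 of the 3 values shown sit, with nothing to set it apart. Compound 4 `CN(C)c1cc2[nH]c(C3CCCCC3)nc2cc1NC(=O)c1ccc(C(C)(C)C)cc1` differs from compound 2 in that (4-(tert-butyl)phenyl in place of 2,2,2-trifluoroethoxy on a carbonyl carbon). Among the compounds with values here, no measured step gives a readable size for an exchange of this kind, so the step of a number no higher from compound 2 to compound 4 (the limit leaves the size open) is expected to stay within the scatter. Compound 4 is therefore expected to give about 100 ug/mL in this assay, within 40 ug/mL to 250 ug/mL, most likely again as a limit.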

Compound 4, half-maximal inhibitory concentration: > 100 ug/mL
Compound 4: only a limit was reported (the forecaster's own chance of this, stated with the estimate: 65%); the middle value sits exactly at the limit.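

Compound 2 and compound 4 both rest on a limit rather than a number, so no size can be read for the step between them: the limit of > 100 ug/mL in this assay, at which 4 of the 4 values shown sit.

The compounds shown leave open what true value lies behind each limit, and whether any exchange of groups shifts this read-out at all.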